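This account rests on a few compounds, and the source may have more. Where it says the series, first, only, none or still open, it means among the compounds named here.

Compound 1 `Cc1cc(=O)c2c(O)cc(OCc3ccccc3)c([C@H]3CCN(C)C[C@H]3O)c2o1`: 24%
Compound 2 `Cc1cc(=O)c2c(O)c(CN(C)CC(=O)O)c(O)c([C@H]3CCN(C)C[C@H]3O)c2o1`: 23%
Compound 3 `Cc1cc(=O)c2c(O)c(CN3CCC(c4ccccc4)CC3)c(O)c([C@H]3CCN(C)C[C@H]3O)c2o1`: 26%

All three compounds were tested in a functional assay on HL-60 cells (Homo sapiens) for inhibition, read by MTT assay, with a stated time of 48 h, tested at 10 uM; a higher number here means more inhibition of growth at the concentration tested, a lower number less inhibition of growth. Compound 3 stands level with the other two: its gaps to compound 1 and compound 2 lie within the usual scatter. Compound 4 `Cc1cc(=O)c2c(O)c(CN3CCCCC3)c(O)c([C@H]3CCN(C)C[C@H]3O)c2o1` changes one place of compound 3: hydrogen in place of phenyl on a saturated ring carbon. Among the measured compounds shown here, no measured pair shows a single change like this one. Compound 2 at 23% and compound 3 at 26% carry quite different side groups, yet their values agree within the scatter, and no step beyond the scatter is expected here. The estimated step of a number 3 percentage points lower from compound 3 to compound 4 (within the scatter) stays within the scatter. For compound 4 the estimate is 23%, with an expected range of 10% to 37%.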

Compound 4, percent growth inhibition at one concentration: 32%
Estimate against measurement, compound 4: 9 percentage points below; the measured number falls inside the stated range.
By their numbers in this assay, from the lowest: compounds 2, 1, 3 and 4 (each within the scatter of the next).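

Measured in this assay the swap of phenyl for hydrogen on this saturated ring carbon gives a number 6 percentage points higher from compound 3 to compound 4 (within the scatter) and so this position takes either group with no step beyond the scatter. Piperidin-1-yl in place of (carboxymethyl)(methyl)amino on the chain carbon gives a number 9 percentage points higher from compound 2 to compound 4 (within the scatter) and this larger change of side group also stays inside the scatter. Nothing measured here offers an explanation for either step. Still open, from the compounds shown here alone, is whether another group on that ring carbon, such as a hydroxyl or a carboxylic acid, would shift growth inhibition beyond the scatter.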